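A few compounds are considered here, and "the series" means these few. Any claim that something is new, unique, unknown or untested is made for them only; others in the source may bear on it.

Among the measured compounds shown here, in an ADME assay on NIH3T3 cells (Mus musculus) for cytotoxicity (a higher number here means that more compound is needed for the effect, a lower number that less compound is needed), compound 2 `Cc1cc(Oc2cccc(Cn3cncn3)c2)cc(C)c1Cl` gives 75900 nM as the only actual number so far. Compound 1 `Clc1ccc(Oc2cccc(Cn3ccnc3)c2)cc1` stands at > 100000 nM as a limit of the assay and not a number. Compound 3 `Cc1nnc(-c2cccc(Oc3cc(C)c(Cl)c(C)c3)c2)o1` carries 5-methyl-1,3,4-oxadiazol-2-yl in place of the (1H-1,2,4-triazol-1-yl)methyl of compound 2 on an aromatic carbon, a swap counted as 5-methyl-1,3,4-oxadiazol-2-yl in place of (1H-1,2,4-triazol-1-yl)methyl on an aromatic carbon with the rest of the structure unchanged. For the measured compounds named here, no measured step bears on this swap, so a 1.1-fold lower number from compound 2 to compound 3 (0.04 log units; within the scatter) is expected to stay within the usual scatter in this assay and to have no clear direction. For compound 3 the estimate is 70000 nM with 30000 nM to 100000 nM as its expected range.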

Compound 3, half-maximal effective concentration: 46100 nM
The estimate for compound 3 lay 1.5-fold (0.18 log units) above the measured number; the measured number falls inside the stated range.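

In this assay, putting 5-methyl-1,3,4-oxadiazol-2-yl in place of (1H-1,2,4-triazol-1-yl)methyl on an aromatic carbon gives a 1.6-fold lower number from compound 2 to compound 3 (0.22 log units; within the scatter), so the two groups cannot be told apart at this position. Among the compounds shown here, this is the first comparison of compounds that differ in one place, and it shows that this change leaves the number within the scatter. The room for reading such changes may be narrow: the limit of > 100000 nM in this assay, at which 1 of the 3 values shown sits.

On these data alone, whether an amine or a carboxylic acid on this carbon would move the number beyond the scatter remains open.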